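A few compounds are considered here, and "the series" means these few. Any claim that something is new, unique, unknown or untested is made for them only; others in the source may bear on it.

Measured compounds and their values:

compound 1 `Cc1cccc(NC(=O)CSC(=S)N[C@H]2CCOC2=O)c1` — > 128000 nM
compound 2 `O=C(CSC(=S)N[C@H]1CCOC1=O)Nc1cccc(Cl)c1` — > 128000 nM
compound 3 `Cc1ccc(NC(=O)CSC(=S)N[C@H]2CCOC2=O)cc1` — 32700 nM

All three share one core and differ only in the substituted phenyl on the amide-type nitrogen. In a functional assay on SMMC-7721 cells (Homo sapiens) for cytotoxicity, read by MTT assay, with a stated time of 72 h (a higher number here means a weaker inhibitor, a lower number a stronger inhibitor), compound 1 reaches only the limit > 128000 nM, not a number. Compound 2 likewise sits at the limit > 128000 nM. Compound 3 is the only one of the three that gives a number, 32700 nM. The values of the other two sit where the assay stops reading (the limit of > 128000 nM in this assay, at which 2 of the 3 values shown sit).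

The two readable steps both end at compound 3: an at least 3.9-fold lower number from compound 1 to compound 3 (0.59 log units; beyond the scatter) and an at least 3.9-fold lower number from compound 2 to compound 3 (0.59 log units; beyond the scatter). The step that the two limits leave unreadable from compound 1 to compound 2 exchanges methyl for chloro, but both ends sit at the limit, so its size cannot be read.

Compound 4 `O=C(CSC(=S)N[C@H]1CCOC1=O)Nc1ccc(F)cc1` keeps the core of compound 3 and changes (fluoro in place of methyl on an aromatic carbon). Going by the values given here, no measured step exchanges methyl for fluoro at this position, so the expectation rests on compound 3 alone, with the moves to the other two 4-substituted... rather, 3-substituted rings serving only as a reminder that the number can fall back to the limit. Compound 4 is therefore estimated at 45000 nM in this assay, between 18000 nM and 128000 nM, an expected step of a 1.4-fold higher number from compound 3 to compound 4 (0.14 log units; within the scatter) that stays within the scatter.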

Compound 4, half-maximal inhibitory concentration: > 128000 nM
Compound 4 was reported as a limit; the forecaster's own chance of this, stated with the estimate: 30%; middle value at least 2.8-fold (0.45 log units) away from the limit.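

Fluoro in place of methyl on the aromatic carbon para to a large group gives an at least 3.9-fold higher number from compound 3 to compound 4 (0.59 log units; beyond the scatter), so in this assay this single exchange is enough to lose the only readable number in the series. Until now, compound 3 was the only compound with a 4-substituted ring, and the step to it from compound 1 could suggest that placing the substituent there was sufficient; compound 4 also carries a 4-substituted ring, yet its result is a limit, so among these compounds the position alone does not secure a number, and the group on it matters as well. The steps from compound 1 and compound 2 to compound 4 cannot be read because both ends of each sit at the same limit: the limit of > 128000 nM in this assay, at which 3 of the 4 values shown sit.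

With only compound 3 giving a number, the compounds shown do not tell how far the other three lie past that limit. They also leave open whether the number depends on methyl specifically or would persist with an ethyl, a methoxy or a chloro group on the same carbon.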